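The compounds below may be only part of what the source reports. "The series", "measured", "known", "first", "only" and "open" are said of these compounds alone.

Measured so far:
Compound 1, `O=[N+]([O-])c1ccccc1NC(CO)CO`: in a functional assay on SW48 cells (Homo sapiens) for cytotoxicity (a higher number here means a weaker inhibitor, a lower number a stronger inhibitor), compound 1 gives > 100000 nM, a limit of the assay rather than a number.
Compound 2, `O=[N+]([O-])c1ccc(NC(CO)CO)c([N+](=O)[O-])c1`: in this assay compound 2 gives > 100000 nM, also a limit.
Compound 3, `O=[N+]([O-])c1cc(C(F)(F)F)ccc1NC(CO)CO`: in this assay compound 3 gives > 100000 nM, again a limit.

Compound 2 thus stands at the limit, as the limit of > 100000 nM in this assay, at which 3 of the 3 values shown sit, records, with no readable number. Compound 4, `O=[N+]([O-])c1ccc(NC(CO)CO)c(C(F)(F)F)c1`, differs from compound 2 by trifluoromethyl in place of nitro on an aromatic carbon. Within the data shown here, the closest measured step is a step that the two limits leave unreadable from compound 2 to compound 3, and a step that the two limits leave unreadable from compound 1 to compound 2 and a step that the two limits leave unreadable from compound 1 to compound 3 are equally unreadable, so no size of step in this assay can be expected from them. On that basis compound 4 is expected to sit near the limit again, an estimated step that the limit leaves unreadable from compound 2 to compound 4. The estimate for compound 4 is 150000 nM, within 50000 nM to 500000 nM.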

Compound 4, half-maximal inhibitory concentration: > 100000 nM
Compound 4: only a limit was reported; the forecaster's own chance of this, stated with the estimate: 85%; the middle value lies beyond the limit too.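

In this assay compound 4 gives only a limit (> 100000 nM), so the step from compound 2 to compound 4 cannot be read. The compounds shown leave open whether any change on the shared core gives a readable value.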